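The compounds below may be only part of what the source reports. "The series", "measured", "known", "first", "only" and "open" are said of these compounds alone.

Working notes on the paw edema series.

Compound 1 `c1ccc(-c2nc(N3CCC(c4ccccc4)CC3)c3ccccc3n2)cc1` is the parent of the first pair. In a functional assay on the whole organism for inhibition, with Rattus norvegicus as the target, read by paw edema, with stated times of 4 days, 1 h and 2 h, at a dose of 100 mg/kg by the oral route (a higher number here means more inhibition at the dose given (going by the name of the read-out), a lower number less inhibition), compound 1 gives 85.3%. Compound 2 `Brc1ccc2nc(-c3ccccc3)nc(N3CCC(c4ccccc4)CC3)c2c1` carries the change bromo in place of hydrogen on an aromatic carbon on the same core. In this assay compound 2 gives 57.6%. For the measured compounds named here, the measured step is a number 27.7 percentage points lower from compound 1 to compound 2 (beyond the scatter), and it is the only measured instance of this change in the set.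

Compound 3 `CC1CCN(c2nc(-c3ccc(Cl)cc3)nc3ccccc23)CC1` belongs to a second core; the difference between the cores of compound 1 and compound 3 is not broken down here. In this assay compound 3 gives 55.1%. The values of compound 2 and compound 3 lie within the scatter of each other, so no order between these two is drawn.

Compound 4 `CC1CCN(c2nc(-c3ccc(Cl)cc3)nc3ccc(Br)cc23)CC1` is not yet measured. It differs from compound 3 by bromo in place of hydrogen on an aromatic carbon. The place is described in the same words as for the change from compound 1 to compound 2, so it is the same change made on the second core. The expectation for compound 4 rests on a single precedent on a different core, so the range is kept wide. For compound 4 the expected step in this assay is a number 23.1 percentage points lower from compound 3 to compound 4 (beyond the scatter), since the same change once gave a number 27.7 percentage points lower from compound 1 to compound 2 (beyond the scatter). In this assay compound 4 is estimated at 32%, with a range from 10% to 55%.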

Compound 4, a percentage reported as inhibition, in the whole organism at one dose (the size of the read-out at that dose, not a potency): 55.1%
Compound 4: the middle estimate sits 23.1 percentage points below what was measured; measured number outside the range, above it.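

In this assay the change of bromo in place of hydrogen on an aromatic carbon does not carry over from one core to the other as a fixed step: the same change on two cores in this assay, a number 27.7 percentage points lower (beyond the scatter) from compound 1 to compound 2 and no change at the digits printed (within the scatter) from compound 3 to compound 4, 27.7 percentage points apart, beyond the scatter of two such steps

On the second core the reading is no change at the digits printed from compound 3 to compound 4 (within the scatter), so the lower number seen on the core of compound 1 does not recur there, and a step measured on one core is a poor guide to the other in this pair of cases. This does not show which part of the difference between the two cores goes with the different outcome, since that difference is not broken down, and with a single pair on each core it establishes no rule for the series as a whole.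

Still open, from the compounds shown here alone, is whether the contrast between the cores belongs to bromo alone or would also appear with another group in the same place, such as methoxy, an amine or a carboxylic acid. Also open, going by these compounds, is how the two cores would compare at other doses, as each step here rests on a single dose in one whole-organism read-out.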